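The compounds below may be only part of what the source reports. "The series", "measured", "known", "first", "only" and "open" are said of these compounds alone.

In an ADME assay on BJ cells (Homo sapiens), read by MTT assay, with a stated time of 72 h (on this read-out lower numbers stand for stronger inhibition and higher numbers for weaker inhibition), compound 1 `COc1ncnc2c1c(-c1ccsc1)cn2[C@@H]1O[C@H](CO)[C@@H](O)[C@H]1O` gives 64300 nM. Compound 2 `CN(C)c1ncnc2c1c(-c1ccsc1)cn2[C@@H]1O[C@H](CO)[C@@H](O)[C@H]1O` returns only the limit of this assay, > 100000 nM, and not a number. Compound 3 `CNc1ncnc2c1c(-c1ccsc1)cn2[C@@H]1O[C@H](CO)[C@@H](O)[C@H]1O` likewise returns only a limit in this assay, > 100000 nM. The step of an at least 1.5-fold higher number from compound 1 to compound 2 (0.19 log units; that floor lies within the scatter) and the step of an at least 1.5-fold higher number from compound 1 to compound 3 (0.19 log units; that floor lies within the scatter) therefore both sit at the floor of what can be read, and the step that the two limits leave unreadable from compound 2 to compound 3 cannot be read at all, as the limit of > 100000 nM in this assay, at which 2 of the 3 values shown sit, shows. Compound 2 thus stands at the upper edge of the measured span, where nothing sharper than a limit is known for it.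

Compound 4 `CN(C)c1ncnc2c1c(-c1cc3ccccc3o1)cn2[C@@H]1O[C@H](CO)[C@@H](O)[C@H]1O` has not yet been measured in this assay. It differs from compound 2 in one place: 1-benzofuran-2-yl in place of thiophen-3-yl on an aromatic carbon. Among the measured compounds shown here, none of the measured steps touches this change; all three concern the exchange among methoxy, dimethylamino and methylamino, so no measured step bears directly on the path from compound 2 to compound 4. With compound 2 at a limit, the account can only expect compound 4 to remain near that limit, and the estimate means a step of an at least 1.1-fold lower number from compound 2 to compound 4 (0.04 log units; that floor lies within the scatter) that is expected to stay within the scatter. For compound 4 the expected value in this assay is 90000 nM, with a range from 25000 nM to 300000 nM.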

Compound 4, half-maximal inhibitory concentration: > 100000 nM
Compound 4: only a limit was reported; the forecaster's own chance of this, stated with the estimate: 60%; middle value at least 1.1-fold (0.04 log units) from the limit.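

Like compound 2, compound 4 returns only a limit, > 100000 nM, so no step from compound 2 to compound 4 can be read: the limit of > 100000 nM in this assay, at which 3 of the 4 values shown sit.

The compounds shown leave open whether 1-benzofuran-2-yl in place of thiophen-3-yl on the shared core makes any difference in this assay.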